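Cytotoxicity of an amidoxime series: adding an anilino-amidoxime arm

This account rests on a few compounds, and the source may have more. Where it says the series, first, only, none or still open, it means among the compounds named here.

Measured compounds:
compound 1, `CC1(Cc2ccccc2)CC(S(=O)(=O)c2ccccc2)=C(c2ccc(/C(N)=N/O)cc2)O1`, 94600 nM
compound 2, `CC1(Cc2ccccc2)CC(S(=O)(=O)c2ccc(/C(N)=N/O)cc2)=C(c2ccc(Nc3cccc(/C(N)=N/O)c3)cc2)O1`, 44000 nM

The read-out here is an ADME assay on THP-1 cells (Homo sapiens) for cytotoxicity, read by flow cytometry, with a stated time of 72 h; on this read-out higher numbers stand for weaker inhibition and lower numbers for stronger inhibition. On it compound 1 gives 94600 nM, the highest number of the two, meaning the weakest inhibition of cell growth in this set. Compound 2 gives 44000 nM, a lower number, and the gap between the two lies beyond the usual scatter. Going by the values given here, no single-point step between measured compounds is available, since the two differ in more than one place.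

Compound 3, `CC1(Cc2ccccc2)CC(S(=O)(=O)c2ccc(Nc3ccccc3/C(N)=N/O)cc2)=C(c2ccc(/C(N)=N/O)cc2)O1`, has not yet been measured. It differs from compound 1 in one spot: a group of 11 heavy atoms (7 carbon, 3 nitrogen, 1 oxygen; one six-membered aromatic ring of carbon only) in place of a hydrogen atom, on an aromatic carbon. Compound 2 also carries an anilino-amidoxime arm, and its value shows a lower number than compound 1, so the same kind of addition in compound 3 is expected to move the number downward, by a moderate amount rather than within the scatter. The step from compound 1 to compound 3 is estimated at a 1.7-fold lower number from compound 1 to compound 3 (0.24 log units; within the scatter). Compound 3 is therefore expected to give about 55000 nM, with a likely range from 20000 nM to 150000 nM.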

Compound 3, half-maximal inhibitory concentration: 48400 nM
Compound 3: middle estimate off by 1.1-fold (0.06 log units), on the high side, and the stated range covers the measured number.
By their numbers in this assay, from the lowest: compounds 2, 3 and 1 (each within the scatter of the next, the first and the last beyond it).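

In this assay, the set now has its first comparison that differs in only one place: a group of 11 heavy atoms, including a six-membered aromatic ring of carbon only, replaces a hydrogen atom on an aromatic carbon, para to a large group, giving a 2.0-fold lower number from compound 1 to compound 3 (0.29 log units; within the scatter). This shows that the aromatic carbon can carry a group of this size without a shift that stands clear of the normal variation between repeated measurements, although a single pair can show no more than that about this position. Nothing shown here offers an explanation for this result.

The compounds shown leave open whether a plain amine on this same aromatic carbon, or a carboxylic acid in place of the amidoxime on the added ring, would give a number that stands apart from compound 1. They also cannot separate the contribution of the added ring from that of its amidoxime, and they do not show whether the same group would behave in the same way on another carbon of that ring.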